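The source may report more compounds than this note shows. Statements on the series, on what has been measured and on what is new or still open speak of the compounds shown alone.

Working notes on the series. In a functional assay on CHO cells for antagonist activity at prostaglandin E2 receptor EP3 subtype (Homo sapiens), read by cAMP accumulation (on this read-out higher numbers stand for weaker inhibition and lower numbers for stronger inhibition), compound 1 `CC(C)C(Cc1nnc[nH]1)c1ccc(-c2ccc3cccc(F)c3c2)[nH]c1=O` gives 17 nM. Compound 2 `CC(C)C(c1ccc(-c2ccc3cccc(F)c3c2)[nH]c1=O)N1CCCCC1=O` gives 40 nM in this assay, and compound 3 `CC(C)C(c1ccc(-c2ccc3cccc(F)c3c2)[nH]c1=O)N1CCN/C1=N\C#N` gives 38 nM in this assay. Compound 3 thus holds the second highest of the three numbers, within the scatter of compound 2, while the step from compound 1 was a 2.2-fold higher number from compound 1 to compound 3 (0.35 log units; beyond the scatter). Compound 4 `CC(C)C(Nc1nccs1)c1ccc(-c2ccc3cccc(F)c3c2)[nH]c1=O` differs from compound 3 by a group of 6 heavy atoms (3 carbon, 2 nitrogen, 1 sulfur; one five-membered aromatic ring with 2 hetero atoms) in place of a group of 8 heavy atoms (4 carbon, 4 nitrogen; one five-membered non-aromatic ring with 2 hetero atoms), on a saturated chain carbon bound to an aromatic carbon and a saturated chain carbon. Going by the values given here, the steps that bear on this are a 2.2-fold higher number from compound 1 to compound 3 (0.35 log units; beyond the scatter), where a five-membered aromatic ring left, and a 1.1-fold lower number from compound 2 to compound 3 (0.02 log units; within the scatter). Compound 4 returns a five-membered aromatic ring, as in compound 1. For compound 4 a modest downward step is expected, a 1.7-fold lower number from compound 3 to compound 4 (0.24 log units; within the scatter) in this assay. Compound 4 is estimated at 22 nM, range 8 nM to 60 nM.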

Compound 4, half-maximal inhibitory concentration: 10 nM
For compound 4 the middle estimate is 2.2-fold (0.34 log units) above the measured one; the measured number falls inside the stated range.
By their numbers in this assay, from the lowest: compounds 4 and 1 (each within the scatter of the next); then compounds 3 and 2 (each within the scatter of the next).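

At this saturated chain carbon, (1,3-thiazol-2-yl)amino separates beyond the scatter from both non-aromatic rings in this assay (a 3.8-fold lower number from compound 3 to compound 4 (0.58 log units; beyond the scatter); a 4.0-fold lower number from compound 2 to compound 4 (0.60 log units; beyond the scatter)). Against (4H-1,2,4-triazol-3-yl)methyl the step stays within the scatter (a 1.7-fold lower number from compound 1 to compound 4 (0.23 log units; within the scatter)), so a second five-membered aromatic ring, with a different link, sits level with compound 1 and apart from compound 2 and compound 3. No supporting measurement accounts for these steps.

Open, as far as these compounds go, is whether the ring or its link carries the step, which (1,3-thiazol-2-yl)methyl would separate. Also open, from the compounds shown here alone, is how a carboxylic acid or a simple dimethylamino group behaves at this carbon.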